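Cytotoxicity notes: phenoxy to 4-fluorophenyl on the shared core

This account rests on a few compounds, and the source may have more. Where it says the series, first, only, none or still open, it means among the compounds named here.

Measured so far in an ADME assay on HepG2 cells (Homo sapiens) for cytotoxicity, read by luminescence, CellTiter-Glo and ATP content, with a stated time of 72 h; a higher number here means that more compound is needed for the effect, a lower number that less compound is needed:
compound 1 `CC(C)Cc1ccc2c(NCCCNCc3ccco3)ccnc2c1` gives 16000 nM
compound 2 `c1ccc(Oc2ccc3c(NCCCNCc4ccco4)ccnc3c2)cc1` gives 15200 nM
compound 3 `COc1ccc(F)cc1CNCCCNc1ccnc2cc(CCC(C)C)ccc12` gives 890 nM

Compound 2 stands second highest of the three numbers; its nearest neighbour is compound 1, and its furthest is compound 3. Among the compounds with values here, the only step of the same kind, a 1.1-fold lower number from compound 1 to compound 2 (0.02 log units; within the scatter), swaps one group on the same aromatic carbon and lands within the scatter. The step to compound 4 `Fc1ccc(-c2ccc3c(NCCCNCc4ccco4)ccnc3c2)cc1` is 4-fluorophenyl in place of phenoxy on an aromatic carbon. Compound 3 differs in its whole side chain and its core substituent, so it does not bear on this exchange. Within the data shown here, with one flat step as the only guide, no step beyond the scatter is expected in this assay. Compound 4 is therefore estimated at 12000 nM, range 5000 nM to 30000 nM, which is expected to mean a 1.3-fold lower number from compound 2 to compound 4 (0.10 log units; within the scatter).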

Compound 4, half-maximal effective concentration: 7760 nM
For compound 4 the middle estimate is 1.5-fold (0.19 log units) above the measured one; measured number inside the range.
By their numbers in this assay, from the lowest: compound 3; then compounds 4, 2 and 1 (each within the scatter of the next, the first and the last beyond it).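

At this aromatic carbon, 4-fluorophenyl in place of phenoxy gives a 2.0-fold lower number from compound 2 to compound 4 (0.29 log units; within the scatter) in this assay and so does not separate the two groups. Against isobutyl, 4-fluorophenyl gives a 2.1-fold lower number from compound 1 to compound 4 (0.31 log units; beyond the scatter) and is the first step at this position to pass the scatter, though only modestly, where phenoxy against isobutyl did not. No measurement at hand offers an explanation for this small shift. Going by these compounds, whether an amine or a carboxylic acid on this carbon would move the number further remains open, as does whether 4-fluorophenyl behaves alike with side chains other than the furan-bearing one.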